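This account rests on a few compounds, and the source may have more. Where it says the series, first, only, none or still open, it means among the compounds named here.

Measured so far in an assay (Cricetulus griseus) for inhibition of aldehyde dehydrogenase, mitochondrial (Homo sapiens); a lower number here means a stronger inhibitor, a higher number a weaker inhibitor:
compound 1 `CC(Oc1ccc2c(=O)c(-c3ccc(O)cc3)coc2c1)C(=O)O` — 2500 nM
compound 2 `O=C(O)CCCCCCCOc1ccc2c(=O)c(-c3ccc(O)cc3)coc2c1` — 40 nM
compound 3 `O=C(O)COc1ccc2c(=O)c(-c3ccc(O)cc3)coc2c1` — 1200 nM

Compound 3 gives the second highest number of the three in this assay; compound 1 lies closest, compound 2 farthest. The step of a 30-fold higher number from compound 2 to compound 3 (1.48 log units; beyond the scatter) is the large one in the set; the step of a 2.1-fold lower number from compound 1 to compound 3 (0.32 log units; beyond the scatter) is modest. Compound 4 `C=CCOc1ccc2c(=O)c(-c3ccc(O)cc3)coc2c1` differs from compound 3 by vinyl in place of carboxy on a saturated chain carbon bound to an oxygen on an aromatic ring. For the measured compounds named here, no measured step removes the carboxy group entirely; both measured steps keep it and vary only the chain it sits on. The large step from compound 2 to compound 3 shows this assay responds strongly to what is attached at the chain carbon bound to the oxygen on the aromatic ring, so the change to compound 4 could move the number either way. Going by the values given here, with no direct precedent, compound 4 is expected near compound 3, with wide uncertainty: the estimated step is a 1.7-fold higher number from compound 3 to compound 4 (0.22 log units; within the scatter). Compound 4 is therefore estimated at 2000 nM, in the range 500 nM to 8000 nM.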

Compound 4, half-maximal inhibitory concentration: 180 nM
The estimate for compound 4 lay 11-fold (1.05 log units) above the measured number, outside the stated range (below it).
By their numbers in this assay, from the lowest: compound 2; then compound 4; then compound 3; then compound 1.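

Removing the carboxy group from the short chain does not cost potency in this assay: vinyl in place of carboxy gives a 6.7-fold lower number from compound 3 to compound 4 (0.82 log units; beyond the scatter), and allyl in place of 1-carboxyethyl gives a 14-fold lower number from compound 1 to compound 4 (1.14 log units; beyond the scatter). A carboxy group is therefore not needed at this position for a number in this range, yet vinyl in place of 6-carboxyhexyl still gives a 4.5-fold higher number from compound 2 to compound 4 (0.65 log units; beyond the scatter), so the long carboxy chain retains an advantage over allyl. Nothing measured on these groups bears on why the numbers move this way.

As far as these compounds go, it remains open whether the low number of compound 2 depends on its carboxy group or on chain length alone; a long unsubstituted alkyl chain, or a long chain ending in an amine, would separate the two. From the compounds shown here alone, whether the double bond of the allyl group matters is also open, and a saturated propyl chain would test it.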